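The source may hold more compounds than are shown below. What is called first, only, known or untested is meant among the compounds shown, and "the series" means these compounds.

Measured in a physicochemical assay for solubility, read by HPLC, in phosphate buffer, measured as kinetic solubility, at pH 7.4; a lower number here means a less soluble compound, a higher number a more soluble compound:
- compound 1 `Cc1c(C(=O)O)cc(-c2ccc(F)cc2)n1-c1ccc(S(N)(=O)=O)cc1`: 50000 nM
- compound 2 `CCC(=O)c1cc(-c2ccc(S(N)(=O)=O)cc2)n(-c2ccc(Cl)cc2)n1`: 41900 nM
- compound 3 `CCC(=O)c1cc(-c2ccc(S(N)(=O)=O)cc2)n(-c2ccc(C(F)(F)F)cc2)n1`: 7500 nM

Compound 3 has the lowest of the three numbers, and the other two compounds both lie above it, beyond the scatter. Still to be measured is compound 4 `CCC(=O)c1cc(-c2ccc(S(N)(=O)=O)cc2)n(-c2ccc(F)cc2)n1`, which differs from compound 3 as follows: fluoro in place of trifluoromethyl on an aromatic carbon. In words, this is fluoro in place of trifluoromethyl on an aromatic carbon.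

Going by the values given here, one measured step bears on this change: a 5.6-fold lower number from compound 2 to compound 3 (0.75 log units; beyond the scatter). That modest step brought in trifluoromethyl in place of chloro on an aromatic carbon. Among the compounds with values here, compound 1 has a different core and gives no matching step. Within the data shown here, no fluoro compound has been measured, so the size remains uncertain. A step of similar or slightly smaller size in the opposite direction is expected in this assay, towards a higher number and beyond the scatter. The expected step is a 4.0-fold higher number from compound 3 to compound 4 (0.60 log units; beyond the scatter). Compound 4 is estimated at 30000 nM, with an expected range from 12000 nM to 60000 nM.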

Compound 4, solubility: 96800 nM
Compound 4: middle estimate off by 3.2-fold (0.51 log units), on the low side; measured number above the stated range.
By their numbers in this assay, from the lowest: compound 3; then compounds 2, 1 and 4 (each within the scatter of the next, the first and the last beyond it).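

In this assay the aromatic carbon para to a large group now carries three measured substituents on the shared core, and fluoro in place of trifluoromethyl gives a 13-fold higher number from compound 3 to compound 4 (1.11 log units; beyond the scatter) as a large step where the earlier step at this position was modest. Fluoro in place of chloro gives a 2.3-fold higher number from compound 2 to compound 4 (0.36 log units; beyond the scatter) as well, so the change to fluoro raises the number against both earlier groups and not only against trifluoromethyl. On this core the numbers run from trifluoromethyl in compound 3 through chloro in compound 2 to fluoro in compound 4, with each step between them beyond the scatter.

As far as these compounds go, whether an amine or a methoxy group at this position would continue that order remains open, as does whether the order holds on the core of compound 1. No measurement shown here accounts for the size of these steps.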